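Lengthening the acid chain of compound 3

The source may report more compounds than this note shows. Statements on the series, on what has been measured and on what is new or still open speak of the compounds shown alone.

For the measured compounds named here, compound 3 `O=C(O)CC[C@H]1CC[C@@H]2[C@@H](/C=C/[C@@H](O)COc3ccccc3)[C@H](O)C[C@@H]2OC1` is one of three compounds measured in an ADME assay on CHO cells for agonist activity at prostacyclin receptor (Homo sapiens), read by HTRF and cAMP accumulation (a lower number here means that less compound is needed, a higher number that more compound is needed for the effect), and in that assay compound 3 gives > 10000 nM, which is a limit of the assay and not a number. Compound 1 `CS(=O)(=O)NC(=O)CCC/C=C\C[C@@H]1[C@@H](/C=C/[C@@H](O)COc2ccccc2)[C@H](O)C[C@@H]1O` gives > 10000 nM in this assay, also a limit. Compound 2 `O=C(O)CC[C@@H]1CC[C@@H]2[C@@H](/C=C/[C@@H](O)COc3ccccc3)[C@H](O)C[C@@H]2OC1` likewise gives > 10000 nM in this assay, again a limit. Going by the values given here, the only measured step, a step that the two limits leave unreadable from compound 2 to compound 3, cannot be read because the limit of > 10000 nM in this assay, at which 3 of the 3 values shown sit, and because of the fact that compounds 2 and 3 differ only in the configuration as drawn. Compound 4 `O=C(O)CCCC[C@H]1CC[C@@H]2[C@@H](/C=C/[C@@H](O)COc3ccccc3)[C@H](O)C[C@@H]2OC1` differs from compound 3 by 2-carboxyethyl in place of carboxy on a saturated chain carbon, two bonds along the chain from a saturated ring carbon. Among the compounds with values here, no measured step bears on this change, so compound 4 is expected to stay near the limit, with a step that the limit leaves unreadable from compound 3 to compound 4 estimated at no readable size. Compound 4 is estimated at 15000 nM, within 3000 nM to 60000 nM.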

Compound 4, half-maximal effective concentration: > 10000 nM
Compound 4: a limit, no number; the forecaster's own chance of this, stated with the estimate: 65%; the middle value lies beyond the limit too.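

The step from compound 3 to compound 4 cannot be read, because both compounds sit at a limit of the assay: the limit of > 10000 nM in this assay, at which 4 of the 4 values shown sit.

The compounds shown leave open whether 2-carboxyethyl in place of carboxy changes the concentration needed for the effect at all.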